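A few compounds are considered here, and "the series" means these few. Any claim that something is new, unique, unknown or untested is made for them only; others in the source may bear on it.

Three compounds sharing one core were tested in a functional assay on the whole organism (strain Wistar) for inhibition, with Rattus norvegicus as the target, read by paw edema, with stated times of 60 min and 6 h, at a dose of 100 mg/kg by the oral route; on this read-out lower numbers stand for less inhibition and higher numbers for more inhibition at the one dose given (going by the name of the read-out). Compound 1 `COc1cc2c(cc1OC)C(CC(=O)NC(C)C)CC2` gives 37%, compound 2 `COc1cc2c(cc1OC)C(CC(=O)NC(C)(C)C)CC2` gives 31.5%, and compound 3 `CCCCCNC(=O)CC1CCc2cc(OC)c(OC)cc21` gives 35.2%, the second highest of the three numbers, lying within the scatter of both others. Compound 4 `COc1cc2c(cc1OC)C(CC(=O)N1CCCCC1)CC2` differs from compound 3 by piperidin-1-yl in place of pentylamino on a carbonyl carbon. The measured steps that also change the group on the amide-type nitrogen are a number 1.8 percentage points lower from compound 1 to compound 3 (within the scatter), a number 3.7 percentage points higher from compound 2 to compound 3 (within the scatter) and a number 5.5 percentage points lower from compound 1 to compound 2 (within the scatter), all within the scatter. On that ground no step beyond the scatter is expected in this assay for compound 4. Compound 4 is therefore estimated at 33%, with a range from 22% to 44%, which corresponds to an expected step of a number 2.2 percentage points lower from compound 3 to compound 4 (within the scatter).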

Compound 4, a percentage reported as inhibition, in the whole organism at one dose (the size of the read-out at that dose, not a potency): 31.5%
The estimate for compound 4 lay 1.5 percentage points above the measured number; measured number inside the range.
By their numbers in this assay, from the lowest: compounds 2, 4, 3 and 1 (each within the scatter of the next).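

In this assay, piperidin-1-yl on the carbonyl carbon, a six-membered ring without a hydrogen-bond donor, gives a number 3.7 percentage points lower from compound 3 to compound 4 (within the scatter), no change at the digits printed from compound 2 to compound 4 (within the scatter) and a number 5.5 percentage points lower from compound 1 to compound 4 (within the scatter). At this place, then, the amide hydrogen carried by all three earlier compounds can be lost, and the chain closed into a ring, without a step beyond the scatter. Going by these compounds, whether a plain amino group or morpholin-4-yl on this carbonyl carbon would also stay within the scatter remains open. No evidence at hand bears on this result.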